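From trifluoromethyl to methyl in the series

The compounds below may be only part of what the source reports. "The series", "measured", "known", "first", "only" and "open" are said of these compounds alone.

In a functional assay on A549 cells (Homo sapiens) for antiproliferative activity, read by MTT assay, with a stated time of 72 h (a higher number here means a weaker inhibitor, a lower number a stronger inhibitor), compound 1 `Cc1nc(C)c(/C=C/C(=O)/C=C/c2ccccc2O)nc1C` gives 4780 nM and compound 2 `Cc1nc(C)c(/C=C/C(=O)/C=C/c2ccc(O)cc2)nc1C` gives 4010 nM, with a 1.2-fold lower number from compound 1 to compound 2 (0.08 log units; within the scatter). Compound 3 `Cc1nc(C)c(/C=C/C(=O)/C=C/c2ccc(C(F)(F)F)cc2)nc1C` has the highest number of the three at 11700 nM.

The change to compound 4 `Cc1ccc(/C=C/C(=O)/C=C/c2nc(C)c(C)nc2C)cc1` is methyl in place of trifluoromethyl on an aromatic carbon, para to a large group. For the measured compounds named here, only one measured step involves a change at this place, a 2.9-fold higher number from compound 2 to compound 3 (0.47 log units; beyond the scatter), which is modest and brought in trifluoromethyl in place of hydroxy. Going by the values given here, no methyl compound has been measured, and hydroxy and methyl are different groups, so this step is only a loose guide. Removing trifluoromethyl from compound 3 is expected to reverse much of a 2.9-fold higher number from compound 2 to compound 3 (0.47 log units; beyond the scatter), giving a modest step towards a lower number in this assay. The expected step is a 2.1-fold lower number from compound 3 to compound 4 (0.33 log units; beyond the scatter). For compound 4 the estimated value is 5500 nM, with an expected range of 2500 nM to 12000 nM.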

Compound 4, half-maximal inhibitory concentration: 4300 nM
Compound 4: the middle estimate sits 1.3-fold (0.11 log units) above what was measured; the range from low to high includes it.
By their numbers in this assay, from the lowest: compounds 2, 4 and 1 (each within the scatter of the next); then compound 3.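

In this assay, methyl in place of trifluoromethyl on this aromatic carbon gives a 2.7-fold lower number from compound 3 to compound 4 (0.43 log units; beyond the scatter), while methyl in place of hydroxy gives a 1.1-fold higher number from compound 2 to compound 4 (0.03 log units; within the scatter), so methyl and hydroxy are not separated here and, of the three groups at this place, only trifluoromethyl stands apart. The 4-methylphenyl group of compound 4 is also not separated from the 2-hydroxyphenyl group, with a 1.1-fold lower number from compound 1 to compound 4 (0.05 log units; within the scatter), which leaves compound 3 alone among the four compounds. No measurement is available that accounts for trifluoromethyl standing apart.

Going by these compounds, whether an amine, a carboxylic acid or a longer chain at this place would stay with methyl and hydroxy or move with trifluoromethyl remains open. Also open, on these data alone, is whether the same grouping would hold in other cell lines.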